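Replacing methoxy with a sulfonyl-bearing group

This account rests on a few compounds, and the source may have more. Where it says the series, first, only, none or still open, it means among the compounds named here.

Measured in a functional assay on MDA-MB-231 cells (Homo sapiens) for antiproliferative activity, read by MTT assay, with a stated time of 72 h; a higher number here means a weaker inhibitor, a lower number a stronger inhibitor:
Compound 1 `NS(=O)(=O)c1ccc(NC(=O)Nc2cccc(-c3nc(-c4ccc(NC(=O)c5cccnc5)cc4Cl)no3)c2)cc1`: > 10000 nM
Compound 2 `COc1ccc(NC(=O)Nc2cccc(-c3nc(-c4ccc(NC(=O)c5cccnc5)cc4Cl)no3)c2)cc1`: 3000 nM

The entry for compound 1 is a limit of the assay, not a number. Among the compounds with values here, compound 2 therefore holds the only actual number so far in this assay. Compound 3 `O=C(Nc1ccc(NS(=O)(=O)C2CC2)cc1)Nc1cccc(-c2nc(-c3ccc(NC(=O)c4cccnc4)cc3Cl)no2)c1` carries (cyclopropylsulfonyl)amino in place of methoxy on an aromatic carbon. Within the data shown here, one measured step bears on this change: an at least 3.3-fold lower number from compound 1 to compound 2 (0.52 log units; beyond the scatter), where methoxy replaced sulfamoyl. Among the measured compounds shown here, compound 3 again carries a sulfonyl group, so that step points towards a weaker inhibitor, though only one step supports this. The expected step is a 2.0-fold higher number from compound 2 to compound 3 (0.30 log units; within the scatter). Compound 3 is estimated at 6000 nM, with an expected range of 2000 nM to 18000 nM.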

Compound 3, half-maximal inhibitory concentration: 300 nM
Compound 3: middle estimate off by 20-fold (1.30 log units), on the high side; measured number outside the range, below it.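

In this assay, (cyclopropylsulfonyl)amino on this aromatic carbon, para to a large group, gives a 10-fold lower number from compound 2 to compound 3 (1.00 log units; beyond the scatter), and an at least 33-fold lower number from compound 1 to compound 3 (1.52 log units; beyond the scatter). Within the data shown here, the one earlier step therefore does not extend to every sulfonyl-bearing group, since compound 3 carries one and is the stronger of the pair with compound 2. The entry for compound 1 is a limit and not a number: the limit of > 10000 nM in this assay, at which 1 of the 3 values shown sits. From the compounds shown here alone, whether the gain rests on the cyclopropyl ring or on the sulfonylamino link stays open, as does how a plain amine or a methylsulfonylamino group would fare at this place.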